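Swapping the amine cap on a tetrahydronaphthalene sulfone

The source may hold more compounds than are shown below. What is called first, only, known or untested is meant among the compounds shown, and "the series" means these compounds.

Measured compounds:
- compound 1, `NC[C@@H]1CCCc2cc(S(=O)(=O)c3cccc(O)c3)ccc21`, 0.251 nM
- compound 2, `CS(=O)(=O)c1cccc(S(=O)(=O)c2ccc3c(c2)CCC[C@H]3CN)c1`, 3.98 nM
- compound 3, `O=C1CN=C(NC[C@@H]2CCCc3cc(S(=O)(=O)c4cccc(F)c4)ccc32)N1`, 0.1 nM

All three were tested in an assay on isolated protein for displacement of a labelled ligand from 5-hydroxytryptamine receptor 6 (Homo sapiens); on this read-out lower numbers stand for stronger inhibition and higher numbers for weaker inhibition. Compound 3 gives the lowest number of the three: compound 1 sits nearest and compound 2 furthest, both gaps beyond the scatter.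

Compound 4, `CN(C)C(=O)NC[C@@H]1CCCc2cc(S(=O)(=O)c3cccc(F)c3)ccc21`, has not been measured. It differs from compound 3 on the amine nitrogen: a group of 5 heavy atoms (3 carbon, 1 nitrogen, 1 oxygen; no ring) in place of a group of 6 heavy atoms (3 carbon, 2 nitrogen, 1 oxygen; one five-membered non-aromatic ring with 2 hetero atoms), on an amine nitrogen.

Among the compounds with values here, the one measured step, a 16-fold higher number from compound 1 to compound 2 (1.20 log units; beyond the scatter), changes a group on the aromatic ring and leaves the amine untouched, so it tells nothing direct about the present change. Within the data shown here, no pair of measured compounds differs only at the amine nitrogen. In the absence of a guiding step, a modest weakening is expected, with a wide range: a 10-fold higher number from compound 3 to compound 4 (1.00 log units; beyond the scatter). Compound 4 is estimated at 1 nM, between 0.2 nM and 5 nM.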

Compound 4, inhibition constant: 2.51 nM
For compound 4 the middle estimate is 2.5-fold (0.40 log units) below the measured one; the range from low to high includes it.
By their numbers in this assay, from the lowest: compound 3; then compound 1; then compounds 4 and 2 (each within the scatter of the next).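

Within the data shown here, this is the first step that touches the amine nitrogen alone. In this assay, dimethylcarbamoyl in place of the ring-bearing group gives a 25-fold higher number from compound 3 to compound 4 (1.40 log units; beyond the scatter), so the group on this nitrogen has a large effect on the read-out when the rest of the molecule stays the same. The swap removes the five-membered ring and also goes from 1 hydrogen-bond donor to 0 hydrogen-bond donors and from 2 hydrogen-bond acceptors to 1 hydrogen-bond acceptor, and no measurement shown here explains the step or separates these differences.

An open-chain group that keeps a hydrogen on its nitrogen, such as methylcarbamoyl, could help to separate the loss of the ring from the loss of the donor. As far as these compounds go, the plain primary amine on the same fluorine-bearing core also remains open, and it would show how much either group on this nitrogen adds.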